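Estimating compound 4 from a repeated tert-butyl to trifluoromethyl swap

The compounds below may be only part of what the source reports. "The series", "measured", "known", "first", "only" and "open" are said of these compounds alone.

Compound 1, `CC(C)(C)c1ccc(CS(=O)(=O)/C=C/c2ccc(O)c(O)c2)cc1`: 12600 nM
Compound 2, `O=S(=O)(/C=C/c1ccc(O)c(O)c1)Cc1ccc(C(F)(F)F)cc1`: 15900 nM
Compound 3, `CC(C)(C)c1ccc(C[S+]([O-])/C=C/c2ccc(O)c(O)c2)cc1`: 9300 nM

Of the compounds shown here, three have been measured in a functional assay on BV-2 cells (Mus musculus) for inhibition, read by Griess assay, with stated times of 3 h and 24 h; on this read-out higher numbers stand for weaker inhibition and lower numbers for stronger inhibition. Compound 1 has the structure `CC(C)(C)c1ccc(CS(=O)(=O)/C=C/c2ccc(O)c(O)c2)cc1` and in this assay compound 1 gives 12600 nM. Compound 2, `O=S(=O)(/C=C/c1ccc(O)c(O)c1)Cc1ccc(C(F)(F)F)cc1`, differs from compound 1 by trifluoromethyl in place of tert-butyl on an aromatic carbon; in this assay compound 2 gives 15900 nM. That change made a 1.3-fold higher number from compound 1 to compound 2 (0.10 log units; within the scatter). Compound 3 has the structure `CC(C)(C)c1ccc(C[S+]([O-])/C=C/c2ccc(O)c(O)c2)cc1` and in this assay compound 3 gives 9300 nM; this value and those of compound 1 and compound 2 lie within the scatter of one another, so no order among the three can be read. The difference between the core of compound 3 and the core of compound 1 is not broken down here.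

Compound 4, `[O-][S+](/C=C/c1ccc(O)c(O)c1)Cc1ccc(C(F)(F)F)cc1`, has not yet been measured. It differs from compound 3 by trifluoromethyl in place of tert-butyl on an aromatic carbon, the same change as from compound 1 to compound 2. Because that change gave a 1.3-fold higher number from compound 1 to compound 2 (0.10 log units; within the scatter), the step from compound 3 to compound 4 in this assay is expected to be of similar size, namely a 1.3-fold higher number from compound 3 to compound 4 (0.11 log units; within the scatter). Compound 4 is therefore estimated at 12000 nM in this assay, with a likely range from 6000 nM to 24000 nM.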

Compound 4, half-maximal inhibitory concentration: 15500 nM
Compound 4: the middle estimate sits 1.3-fold (0.11 log units) below what was measured; low and high end bracket the measured number.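

Carried to the second core, trifluoromethyl in place of tert-butyl gave a 1.7-fold higher number from compound 3 to compound 4 (0.22 log units; within the scatter) in this assay. Set beside the earlier step, the change reads alike on the two cores: the same change on two cores in this assay, a 1.3-fold higher number (0.10 log units; within the scatter) from compound 1 to compound 2 and a 1.7-fold higher number (0.22 log units; within the scatter) from compound 3 to compound 4, 1.3-fold (0.12 log units) apart, within the scatter of two such steps. That agreement is all the pair shows; each step lies within the scatter, so it remains unshown that the swap moves the number at all, and two cores give no rule for any other core.

The compounds shown carry only tert-butyl or trifluoromethyl at this place on the aromatic ring, which leaves open what an amine, a carboxylic acid or a longer chain there would do to the number. Also open, as far as these compounds go, is whether the swap would read the same way on a core with an amide in place of the sulfur-bearing link.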